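A few compounds are considered here, and "the series" means these few. Any claim that something is new, unique, unknown or untested is made for them only; others in the source may bear on it.

Measured in an assay on isolated protein for binding affinity to serine protease 1 (Bos taurus); on this read-out higher numbers stand for weaker inhibition and lower numbers for stronger inhibition:

compound 1, `CN(C)c1cccc2c(S(=O)(=O)NC(CCCN=C(N)N)C(=O)N3CCCCC3)cccc12`: 2340 nM
compound 2, `CC/N=C(/N)NCCCC(NS(=O)(=O)c1cccc2c(N(C)C)cccc12)C(=O)N1CCCCC1`: 337000 nM
compound 3, `CN(C)c1cccc2c(S(=O)(=O)NC(CCCNC3=NCCN3)C(=O)N3CCCCC3)cccc12`: 116000 nM

Compound 3 stands second highest of the three numbers in this assay. Its nearest neighbour is compound 2, which gave a 2.9-fold lower number from compound 2 to compound 3 (0.46 log units; beyond the scatter); the furthest is compound 1, from which the step was a 50-fold higher number from compound 1 to compound 3 (1.70 log units; beyond the scatter).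

The step from compound 3 to compound 4, `CN(C)c1cccc2c(S(=O)(=O)NC(CCCN3CCN=C3N)C(=O)N3CCCCC3)cccc12`, is a rearrangement: a group of 6 heavy atoms (3 carbon, 3 nitrogen; one five-membered non-aromatic ring with 2 hetero atoms) in place of a group of 6 heavy atoms (3 carbon, 3 nitrogen; one five-membered non-aromatic ring with 2 hetero atoms), on a saturated chain carbon, four bonds along the chain from a carbonyl carbon and a sulfonamide nitrogen. The same atoms are present in both, joined differently, so the five-membered ring stays and only the point at which the chain meets it moves.

The measured steps bear on this only indirectly. Both substitutions on the terminal group of compound 1 were costly: a 140-fold higher number from compound 1 to compound 2 (2.16 log units; beyond the scatter) and a 50-fold higher number from compound 1 to compound 3 (1.70 log units; beyond the scatter). Between the two substituted forms the gap was smaller: a 2.9-fold lower number from compound 2 to compound 3 (0.46 log units; beyond the scatter). For the measured compounds named here, no measured pair shows a rearrangement of this kind, so the expectation for compound 4 rests on compound 3 alone, with the chance of a further modest loss or gain. Compound 4 is therefore expected to give 150000 nM in this assay, within 30000 nM to 700000 nM, a step of a 1.3-fold higher number from compound 3 to compound 4 (0.11 log units; within the scatter) that is expected to stay near the scatter.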

Compound 4, inhibition constant: 278000 nM
For compound 4 the middle estimate is 1.9-fold (0.27 log units) below the measured one; measured number inside the range.
By their numbers in this assay, from the lowest: compound 1; then compound 3; then compounds 4 and 2 (each within the scatter of the next).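

Moving the point at which the chain meets the five-membered ring is not a neutral change in this assay (a 2.4-fold higher number from compound 3 to compound 4 (0.38 log units; beyond the scatter)), even though the two groups hold the same atoms; the group that enters carries 1 hydrogen-bond donor where the group that leaves carries 2. At this saturated chain carbon, the rearranged ring group cannot be told apart from the open-chain group of compound 2 (a 1.2-fold lower number from compound 2 to compound 4 (0.08 log units; within the scatter)), while it stays far from the terminal group of compound 1 (a 120-fold higher number from compound 1 to compound 4 (2.07 log units; beyond the scatter)), so that none of the three substituted groups shown comes close to the number of compound 1. Nothing measured here accounts for these differences.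

The compounds shown leave open whether a smaller addition to the terminal group of compound 1, such as a single methyl, would cost less than the groups seen so far. They also leave open how a six-membered ring in place of the five-membered one, or a longer chain carrying either ring group, would read in this assay.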